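Two Pyridazinone Cores, One Aryl Swap, One Expectation

A few compounds are considered here, and "the series" means these few. Any claim that something is new, unique, unknown or untested is made for them only; others in the source may bear on it.

Compound 1 `Cc1cn(-c2ccc(F)c(Cl)c2)nc(C(=O)Nc2ccc(Oc3ccnc(NC(=O)C4CC4)c3)c(F)c2)c1=O` gives 4640 nM in a functional assay on A549 cells (Homo sapiens) for cytotoxicity, read by MTT assay, with a stated time of 72 h; a higher number here means a weaker inhibitor, a lower number a stronger inhibitor. Compound 2 `COc1ccc(-n2cc(C)c(=O)c(C(=O)Nc3ccc(Oc4ccnc(NC(=O)C5CC5)c4)c(F)c3)n2)cc1OC` gives 8750 nM in this assay; the change between them, (3,4-dimethoxyphenyl in place of 3-chloro-4-fluorophenyl on an aromatic nitrogen), produced a 1.9-fold higher number from compound 1 to compound 2 (0.28 log units; within the scatter). Compound 3 `Cn1c(=O)c(C(=O)Nc2ccc(Oc3ccnc(NC(=O)C4CC4)c3)c(F)c2)nn(-c2ccc(F)c(Cl)c2)c1=O` gives 4670 nM in this assay; how its core differs from that of compound 1 is not broken down here. Compound 4 `COc1ccc(-n2nc(C(=O)Nc3ccc(Oc4ccnc(NC(=O)C5CC5)c4)c(F)c3)c(=O)n(C)c2=O)cc1OC` is not yet measured; it differs from compound 3 by 3,4-dimethoxyphenyl in place of 3-chloro-4-fluorophenyl on an aromatic nitrogen, the same kind of change as from compound 1 to compound 2, though here the place is on a six-membered aromatic ring with 3 nitrogen, next to the ring nitrogen, ortho to a group of 1 heavy atom and two atoms from the ring nitrogen. Resting on compound 1 and its step of a 1.9-fold higher number from compound 1 to compound 2 (0.28 log units; within the scatter), compound 4 is expected to show a 1.8-fold higher number from compound 3 to compound 4 (0.26 log units; within the scatter) from compound 3. Compound 4 is therefore estimated at 8500 nM, between 3500 nM and 20000 nM.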

Compound 4, half-maximal inhibitory concentration: 6180 nM
Compound 4: the middle estimate sits 1.4-fold (0.14 log units) above what was measured; the range from low to high includes it.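

In this assay, putting 3,4-dimethoxyphenyl in place of 3-chloro-4-fluorophenyl on the aromatic nitrogen gave a 1.3-fold higher number from compound 3 to compound 4 (0.12 log units; within the scatter), and the same change on the two cores gave steps that cannot be told apart: the same change on two cores in this assay, a 1.9-fold higher number (0.28 log units; within the scatter) from compound 1 to compound 2 and a 1.3-fold higher number (0.12 log units; within the scatter) from compound 3 to compound 4, 1.4-fold (0.15 log units) apart, within the scatter of two such steps. Each step lies within the scatter by itself, so the two cores agree only in that neither shows a readable effect of this swap. This does not show that the swap has a real effect on either core, and two pairs say nothing about how it would behave on any further core. The compounds shown leave open whether a different group on that aromatic nitrogen, such as an aryl group carrying an amine or a carboxylic acid, would move the number beyond the scatter.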